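Chloro for fluoro on the core of compound 1

The compounds below may be only part of what the source reports. "The series", "measured", "known", "first", "only" and "open" are said of these compounds alone.

In an ADME assay on microsomes from liver (Homo sapiens) for metabolic stability (on this read-out higher numbers stand for fast clearance and lower numbers for slow clearance), compound 1 `O=C(Nc1ccc(Cl)cc1)C(=O)N1CCC(c2ccnc3ccc(F)cc23)CC1` gives 9 mL.min-1.g-1 and sits at the low end of the three measured numbers. Compound 2 `O=C(Nc1ccc(Cl)cc1F)C(=O)N1CCC(c2ccnc3ccc(F)cc23)CC1` stays close to it with 10 mL.min-1.g-1 as its number. Compound 3 `O=C(Nc1ccc(Cl)cn1)C(=O)N1CCC(c2ccnc3ccc(F)cc23)CC1` gives 23 mL.min-1.g-1 as the high number of the set. The steps that reach it are a 2.6-fold higher number from compound 1 to compound 3 (0.41 log units; beyond the scatter) and a 2.3-fold higher number from compound 2 to compound 3 (0.36 log units; beyond the scatter) and both exchange the group on the amide-type nitrogen.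

The change to compound 4 `O=C(Nc1ccc(Cl)cc1)C(=O)N1CCC(c2ccnc3ccc(Cl)cc23)CC1` is chloro in place of fluoro on an aromatic carbon and the rest of compound 1 stays the same. Within the data shown here, no measured step touches that place. The closest in kind is a 1.1-fold higher number from compound 1 to compound 2 (0.05 log units; within the scatter) which also concerns a single halogen on an aromatic carbon, though elsewhere in the molecule. The larger steps involve a different kind of exchange and offer only weak guidance. No step beyond the scatter is therefore expected in this assay for this exchange. The estimated step is a 1.3-fold higher number from compound 1 to compound 4 (0.12 log units; within the scatter) and it is expected to stay small. Compound 4 is expected at 12 mL.min-1.g-1 with 6 mL.min-1.g-1 to 24 mL.min-1.g-1 as the estimated range.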

Compound 4, intrinsic clearance in microsomes: 11 mL.min-1.g-1
The estimate for compound 4 lay 1.1-fold (0.04 log units) above the measured number; low and high end bracket the measured number.
By their numbers in this assay, from the lowest: compounds 1, 2 and 4 (each within the scatter of the next); then compound 3.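

Among these compounds, until now no measured step touched the halogen on the core, and in this assay the new step (a 1.2-fold higher number from compound 1 to compound 4 (0.09 log units; within the scatter)) shows that chloro can stand in place of fluoro at this position without moving the number beyond the scatter. Both single-halogen changes now stay within the scatter, including the fluoro in place of hydrogen elsewhere in the molecule (a 1.1-fold higher number from compound 1 to compound 2 (0.05 log units; within the scatter)), while exchanging the group on the amide-type nitrogen goes beyond it (a 2.6-fold higher number from compound 1 to compound 3 (0.41 log units; beyond the scatter)). No evidence on what lies behind this result is at hand.

Going by these compounds, whether this position would accept something other than a halogen, such as an amine, a methoxy group or a nitrile, remains open. So does whether chloro in place of fluoro gives an equally small step when 5-chloropyridin-2-yl sits on the amide-type nitrogen.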